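The source may hold more compounds than are shown below. What is called first, only, known or untested is meant among the compounds shown, and "the series" means these compounds.

Measured so far in an ADME assay on cells (Macrophage, Mus musculus) for cytotoxicity, read by resazurin assay, with a stated time of 3 days; on this read-out higher numbers stand for weaker inhibition and lower numbers for stronger inhibition
- Compound 1 `O=C(Nc1cccc(C(F)(F)F)c1)c1cc(Cl)ccc1O` gives 5900 nM
- Compound 2 `O=C(Nc1cc(C(F)(F)F)ccc1F)c1cc(Cl)ccc1O` gives 2600 nM
- Compound 3 `O=C(Nc1ccc(Br)c(C(F)(F)F)c1)c1cc(Cl)ccc1O` gives 4500 nM

Compound 1 and compound 3 stand together at the upper end of these three numbers, and only compound 2 separates from compound 1 beyond the scatter. Next in the series is compound 4 `COc1cc(NC(=O)c2cc(Cl)ccc2O)cc(C(F)(F)F)c1`, which carries methoxy in place of hydrogen on an aromatic carbon, meta to a trifluoromethyl group (methoxy in place of hydrogen on an aromatic carbon). Among the compounds with values here, no measured compound carries methoxy, so the nearest guides are the two other replacements of hydrogen on an aromatic carbon. Fluoro gives a 2.3-fold lower number from compound 1 to compound 2 (0.36 log units; beyond the scatter), a modest change. Bromo gives a 1.3-fold lower number from compound 1 to compound 3 (0.12 log units; within the scatter). Within the data shown here, both point the same way, but they are only two steps and they differ in size, so they support a weak expectation. In this assay a small move to a lower number is expected for methoxy, probably no larger than the fluoro step and quite possibly lost in the scatter. The estimated change is a 1.5-fold lower number from compound 1 to compound 4 (0.17 log units; within the scatter). For compound 4 the expected value is 4000 nM, with an estimated range from 1800 nM to 8500 nM.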

Compound 4, half-maximal inhibitory concentration: 18000 nM
Beside the measured number, compound 4's estimate is 4.5-fold (0.65 log units) below it, and the stated range ends below it.
By their numbers in this assay, from the lowest: compounds 2, 3 and 1 (each within the scatter of the next, the first and the last beyond it); then compound 4.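

In this assay, methoxy on an aromatic carbon, meta to a trifluoromethyl group, gives a 3.1-fold higher number from compound 1 to compound 4 (0.48 log units; beyond the scatter), the only step shown from compound 1 that goes to a higher number beyond the scatter. The other two replacements of hydrogen do not go that way: fluoro gives a 2.3-fold lower number from compound 1 to compound 2 (0.36 log units; beyond the scatter), and bromo gives a 1.3-fold lower number from compound 1 to compound 3 (0.12 log units; within the scatter), so replacing hydrogen on this ring of the core has no single direction across compounds 2, 3 and 4, and the sign of the step varies with the group entering or with its place. No measurement available here explains why methoxy departs from the other two replacements.

Going by these compounds, it remains open whether this higher number belongs to methoxy itself or to its place meta to a trifluoromethyl group, since fluoro and bromo do not occupy that same place and a single methoxy compound cannot separate the two readings. Also open, on these data alone, is how a hydroxy group, an amine or a longer chain such as ethoxy would read at the same aromatic carbon, and whether any of them would follow methoxy in direction and size.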